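This account rests on a few compounds, and the source may have more. Where it says the series, first, only, none or still open, it means among the compounds named here.

In a functional assay on NALM-6 cells (Homo sapiens) for cytotoxicity, with a stated time of 72 h (on this read-out higher numbers stand for an effect only at larger amounts of compound and lower numbers for an effect already at smaller amounts), compound 1 `C=C[C@@](C)(/C=C/c1ccc(O)c(CO)c1)CCC=C(C)C` gives 16400 nM. Going by these compounds, compound 2 `C=C[C@@](C)(/C=C/c1ccc(O)c(/C=C/C(N)=O)c1)CCC=C(C)C` reaches only a limit of the assay, > 43400 nM, so its true position remains unknown. The next analogue, compound 3 `C=C[C@@](C)(/C=C/c1ccc(O)c(/C=C/c2ccc(F)cc2)c1)CCC=C(C)C`, carries 4-fluorophenyl in place of carbamoyl on a double-bonded chain carbon bound to a double-bonded chain carbon, placing 4-fluorophenyl in place of carbamoyl on a double-bonded chain carbon bound to a double-bonded chain carbon. Going by the values given here, the only measured step that bears on this change is an at least 2.6-fold higher number from compound 1 to compound 2 (0.42 log units; beyond the scatter), and it offers indirect guidance since it involves different groups. With the limit as the starting point, a modest move toward lower numbers is expected, namely an at least 2.1-fold lower number from compound 2 to compound 3 (0.33 log units; beyond the scatter). Compound 3 is estimated at 20000 nM, with an expected range from 7000 nM to 50000 nM.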

Compound 3, half-maximal effective concentration: > 43400 nM
Compound 3 gave a limit, no number (the forecaster's own chance of this, stated with the estimate: 35%); middle value at least 2.1-fold (0.33 log units) from the limit.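

In this assay compound 3 also ends at a limit, > 43400 nM, not at a number. Hydroxymethyl on this aromatic carbon now has a second replacement, 2-(4-fluorophenyl)ethenyl, and it gives an at least 2.6-fold higher number from compound 1 to compound 3 (0.42 log units; beyond the scatter), so the shift away from compound 1 holds with a carbamoyl or a 4-fluorophenyl at the chain end. The step between the two replacements cannot be read, and what blocks it is this: the limit of > 43400 nM in this assay, at which 2 of the 3 values shown sit.

Going by these compounds, how far apart compound 2 and compound 3 truly lie stays open. So does whether an amine or a carboxylic acid on this aromatic carbon would give a readable number.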